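This account rests on a few compounds, and the source may have more. Where it says the series, first, only, none or still open, it means among the compounds named here.

Measured in a functional assay on MCF7 cells (Homo sapiens) for cytotoxicity, read by MTT assay, with a stated time of 48 h; on this read-out higher numbers stand for weaker inhibition and lower numbers for stronger inhibition:
- Compound 1 `COc1ccc(-c2nnc(SCCn3c([N+](=O)[O-])cnc3C)o2)cc1`: 10600 nM
- Compound 2 `Cc1ncc([N+](=O)[O-])n1CCSc1nnc(-c2ccccc2[N+](=O)[O-])o1`: 18300 nM
- Compound 3 `Cc1ncc([N+](=O)[O-])n1CCSc1nnc(-c2ccc(N(C)C)cc2)o1`: 14900 nM

Compound 1 stands level with the other two, since all three values lie within the usual scatter of one another. Compound 4 `Cc1cccc(-c2nnc(SCCn3c([N+](=O)[O-])cnc3C)o2)c1O` keeps the core of compound 1 but carries 2-hydroxy-3-methylphenyl in place of 4-methoxyphenyl on an aromatic carbon. Among the measured compounds shown here, the one measured step that bears on this is small: a 1.4-fold higher number from compound 1 to compound 3 (0.15 log units; within the scatter), with dimethylamino in place of methoxy on an aromatic carbon. For the measured compounds named here, no measured compound carries a hydroxy group, so this is only a loose guide. A step beyond the scatter, in either direction, is therefore not expected in this assay. For compound 4 the estimated value is 10000 nM, with an expected range from 3000 nM to 25000 nM. This estimate means an expected step of a 1.1-fold lower number from compound 1 to compound 4 (0.03 log units; within the scatter).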

Compound 4, half-maximal inhibitory concentration: 19900 nM
Compound 4: middle estimate off by 2.0-fold (0.30 log units), on the low side; low and high end bracket the measured number.
By their numbers in this assay, from the lowest: compounds 1, 3, 2 and 4 (each within the scatter of the next).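

In this assay the change from 4-methoxyphenyl to 2-hydroxy-3-methylphenyl gives a 1.9-fold higher number from compound 1 to compound 4 (0.27 log units; within the scatter) and so stays inside the scatter. Among the compounds shown here, this is the first compound here with a hydrogen-bond donor on this aromatic group, and the same count of heavy atoms arranged differently leaves the number within that scatter. Nothing available explains the size of this step.

As far as these compounds go, whether a carboxylic acid or an amine on this phenyl ring would produce a step beyond the scatter remains open. From the compounds shown here alone, the separate contributions of the hydroxy and the methyl also remain open.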